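Title: From a methyl ring to a hydroxy ring on a shared core

The source may hold more compounds than are shown below. What is called first, only, known or untested is meant among the compounds shown, and "the series" means these compounds.

Measured compounds:
Compound 1, `COc1cccc(/C=C2\NS(=O)(=O)c3ccccc3C2=O)c1`, gives 1040 nM.
Compound 2, `O=C1/C(=C/c2ccccc2Br)NS(=O)(=O)c2ccccc21`, gives 7430 nM.
Compound 3, `Cc1ccccc1/C=C1\NS(=O)(=O)c2ccccc2C1=O`, gives 3750 nM.

All three share one core and differ only in the aromatic group hanging from the double-bonded chain carbon. In an assay for inhibition of Intestinal-type alkaline phosphatase (Homo sapiens), read by spectrophotometry, with stated times of 10 min and 20 min (on this read-out higher numbers stand for weaker inhibition and lower numbers for stronger inhibition), compound 3 stands second highest of the three numbers; its nearest neighbour is compound 2, and the step of a 2.0-fold lower number from compound 2 to compound 3 (0.30 log units; within the scatter) is within the scatter, so nothing can be said of their order. Compound 1 sits furthest away with a lower number beyond the scatter.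

Compound 4, `O=C1/C(=C/c2cccc(O)c2)NS(=O)(=O)c2ccccc21`, has not yet been measured. It differs from compound 3 in one place: 3-hydroxyphenyl in place of 2-methylphenyl on a double-bonded chain carbon bound to a double-bonded ring carbon. Among the measured compounds shown here, only one measured step changes a group on that aromatic ring, a 2.0-fold lower number from compound 2 to compound 3 (0.30 log units; within the scatter), and it was within the scatter; no measured step swaps a methyl for a hydroxy, nor moves the group from one ring carbon to another. Compound 1 carries a methoxy group on the same ring and gives 1040 nM, which hints that a group of this kind at this place is tolerated. The estimate for compound 4 is therefore a modestly lower number, with a wide range: 1500 nM, from 500 nM to 5000 nM. The expected step is a 2.5-fold lower number from compound 3 to compound 4 (0.40 log units; beyond the scatter).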

Compound 4, half-maximal inhibitory concentration: 1210 nM
Compound 4: middle estimate off by 1.2-fold (0.09 log units), on the high side, and the stated range covers the measured number.
By their numbers in this assay, from the lowest: compounds 1 and 4 (each within the scatter of the next); then compounds 3 and 2 (each within the scatter of the next).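

In this assay, the change to 3-hydroxyphenyl gives a clear shift when it replaces 2-methylphenyl (a 3.1-fold lower number from compound 3 to compound 4 (0.49 log units; beyond the scatter)) and a larger one when it replaces 2-bromophenyl (a 6.1-fold lower number from compound 2 to compound 4 (0.79 log units; beyond the scatter)). Unlike the swap of bromo for methyl (a 2.0-fold lower number from compound 2 to compound 3 (0.30 log units; within the scatter)), both of these steps lie beyond the scatter, so the aromatic group at this place can change the number measurably. Removing the methyl from the oxygen of the methoxy group (a 1.2-fold higher number from compound 1 to compound 4 (0.07 log units; within the scatter)) stays within the scatter, so hydroxy and methoxy on this ring cannot be told apart here, and no measurement shown explains any of these steps.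

From the compounds shown here alone, the replacement of 2-methylphenyl changes both the group and the ring carbon carrying it, so the effect of each alone remains open. Also open, going by these compounds, is whether an amine or a carboxylic acid on this ring would give a number like that of the hydroxy compound.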